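This account rests on a few compounds, and the source may have more. Where it says the series, first, only, none or still open, it means among the compounds named here.

Measured compounds:
Compound 1 `COc1ccc(CNc2ncnc3c2ncn3C2CCCCO2)c(OC)c1`: > 25000 nM
Compound 2 `COc1cc(OC)c(OC)cc1CNc1ncnc2c1ncn2C1CCCCO1`: > 100000 nM

Both compounds were tested in an ADME assay on K562 cells (Homo sapiens) for cytotoxicity, with a stated time of 72 h (on this read-out higher numbers stand for weaker inhibition and lower numbers for stronger inhibition), and neither gave a number. In this assay compound 1 gives > 25000 nM, which is a limit of the assay. In the same assay compound 2 gives > 100000 nM, which is also a limit. Compound 2 therefore has no exact place on the scale, and the only other result available is a limit as well.

Compound 3 `COc1cc(OC)c(OC)cc1CNc1ncnc2c1ncn2C1CCCO1` differs from compound 2 in one group, with oxolan-2-yl in place of oxan-2-yl on an aromatic nitrogen. Within the data shown here, the only measured step, a step that the two limits leave unreadable from compound 1 to compound 2, is methoxy in place of hydrogen on an aromatic carbon. That change lies at another place, and its size cannot be read. Among the measured compounds shown here, no measured step covers the group that changes here, so no step beyond the usual scatter is expected in this assay, and no direction can be assigned. The expected change is a number no higher from compound 2 to compound 3 (the limit leaves the size open). For compound 3 the estimate is 100000 nM, with an expected range of 30000 nM to 300000 nM.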

Compound 3, half-maximal inhibitory concentration: > 100000 nM
Compound 3: only a limit was reported; the forecaster's own chance of this, stated with the estimate: 80%; the middle value lies on the limit itself.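

In this assay compound 3 gives > 100000 nM, which is a limit of the assay. Among these compounds, compound 2 gives > 100000 nM, also a limit, so no step between compound 2 and compound 3 can be read. The compounds shown leave open where any of them sits on the scale of this assay, and whether oxolan-2-yl in place of oxan-2-yl changes the read-out at all.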